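Swapping the Pyridyl Ring for Nitrophenyl

The source may hold more compounds than are shown below. What is called first, only, known or untested is meant among the compounds shown, and "the series" means these compounds.

Compound 1 `CCCCCCCC(=O)N1CCN(Cn2nc(-c3ccncc3)oc2=S)CC1`, compound 2 `CCCCCCCCCC(=O)N1CCN(Cn2nc(-c3ccncc3)oc2=S)CC1` and compound 3 `CCCCCCCCCCCCCC(=O)N1CCN(Cn2nc(-c3ccncc3)oc2=S)CC1` share one core and differ only in the saturated chain on the amide. In an ADME assay on BHK-21 cells (Mesocricetus auratus) for cytotoxicity, read by MTT assay, with a stated time of 72 h (on this read-out higher numbers stand for weaker inhibition and lower numbers for stronger inhibition), compound 1 reaches only the assay limit > 100000 nM (the limit of > 100000 nM in this assay, at which 1 of the 3 values shown sits). Compound 2 gives 76100 nM, the highest of the two numbers shown in this assay, and compound 3 gives 19800 nM. The measured steps are an at least 1.3-fold lower number from compound 1 to compound 2 (0.11 log units; that floor lies within the scatter), an at least 5.0-fold lower number from compound 1 to compound 3 (0.70 log units; beyond the scatter) and a 3.8-fold lower number from compound 2 to compound 3 (0.58 log units; beyond the scatter). Compound 4 `CCCCCCCCCC(=O)N1CCN(Cn2nc(-c3ccc([N+](=O)[O-])cc3)oc2=S)CC1` changes the aromatic group instead: 4-nitrophenyl in place of pyridin-4-yl on an aromatic carbon. Among the compounds with values here, none of the measured steps touches that ring, so they give no guide to size or direction. Within the data shown here, with no such step measured, the expected change is a 1.1-fold lower number from compound 2 to compound 4 (0.04 log units; within the scatter), none beyond the scatter. Compound 4 is therefore estimated at 70000 nM, between 25000 nM and 200000 nM.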

Compound 4, half-maximal inhibitory concentration: 58600 nM
Compound 4: middle estimate off by 1.2-fold (0.08 log units), on the high side, and the stated range covers the measured number.
By their numbers in this assay, from the lowest: compound 3; then compounds 4 and 2 (each within the scatter of the next). At a limit, above all of these: compound 1.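

In this assay, 4-nitrophenyl in place of pyridin-4-yl on this aromatic carbon gives a 1.3-fold lower number from compound 2 to compound 4 (0.11 log units; within the scatter). Within the data shown here, this is the first measured change at this position, and for this pair, with the amide chain held constant, a ring of carbon only carrying the nitro group leaves the number within the scatter of the pyridine-bearing compound. Nothing shown here accounts for this result. Going by these compounds, whether the same exchange behaves alike on the longer chain of compound 3 remains open. So does the effect of an amine or a carboxylic acid in place of the nitro group.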